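This account rests on a few compounds, and the source may have more. Where it says the series, first, only, none or still open, it means among the compounds named here.

Compound 1 `CCCCn1ccc(N2CCC(c3ccccc3)CC2)c(C#N)c1=O` reaches 309% in a functional assay on CHO cells for positive allosteric modulation of metabotropic glutamate receptor 2 (Homo sapiens), with a stated time of 30 min; a higher number here means a larger maximal response, a lower number a smaller maximal response. Compound 2 `N#Cc1c(N2CCC(c3ccccc3)CC2)ccn(CC2CCC2)c1=O` reaches 269% in this assay.

Going by the values given here, of these two numbers, compound 2 stands lowest; the only neighbour is compound 1, and the step of a number 40 percentage points lower from compound 1 to compound 2 (beyond the scatter) separates them beyond the usual scatter. Compound 3 `N#Cc1c(N2CCC(c3ccccc3)CC2)ccn(CC2CC2)c1=O` is built from compound 2 by a change at the same place: cyclopropyl in place of cyclobutyl on a saturated chain carbon bound to an aromatic nitrogen.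

Among the compounds with values here, the only measured step that bears on this change is a number 40 percentage points lower from compound 1 to compound 2 (beyond the scatter), in which cyclobutyl replaced propyl on a saturated chain carbon bound to an aromatic nitrogen and the maximal response fell by a large amount. That step traded an open chain for a four-membered ring; the new step trims the four-membered ring to a three-membered one, a smaller alteration of the same substituent. Nothing measured shows which way a ring of this size moves the response, so a step no larger than the scatter is expected, in either direction. Compound 3 is therefore estimated at 275% in this assay, within 210% to 340%, which corresponds to an expected step of a number 6 percentage points higher from compound 2 to compound 3 (within the scatter).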

Compound 3, largest response reached (Emax), in percent of the reference or control that the assay uses: 309%
Compound 3: middle estimate off by 34 percentage points, on the low side; measured number inside the range.
By their numbers in this assay, from the lowest: compound 2; then compounds 1 and 3 (each within the scatter of the next).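

In this assay, the step of a number 40 percentage points higher from compound 2 to compound 3 (beyond the scatter) reverses the earlier fall, so the response at this position depends on the ring that stands there and not merely on the presence of a ring. The step of no change at the digits printed from compound 1 to compound 3 (within the scatter) shows that a saturated ring as such need not lower the response, since cyclopropyl and propyl on this saturated chain carbon bound to an aromatic nitrogen give matching numbers, leaving compound 2, with its cyclobutyl, as the only one of the three set apart. No measurement is available that explains why the four-membered ring differs from the three-membered ring or from the open chain.

The three compounds cannot show whether a cyclopentyl group in the same place would keep the lower response of compound 2, or whether the cyclobutyl result is an isolated dip among the rings. They also leave open how a longer chain such as hexyl, or a chain carrying an ether oxygen such as methoxyethyl, would fare at this position, and whether the response seen with propyl and cyclopropyl can be exceeded there.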